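The source may report more compounds than this note shows. Statements on the series, on what has been measured and on what is new or still open speak of the compounds shown alone.

Compound 1 `O=C1C=CC2(C=C1)OC(=O)C(c1cc3ccccc3s1)=C2c1ccccc1` carries a 1-benzothiophen-2-yl group on a double-bonded ring carbon of the shared core. In a functional assay on MDA-MB-231 cells (Homo sapiens) for antiproliferative activity, read by MTT assay, with a stated time of 48 h (a higher number here means a weaker inhibitor, a lower number a stronger inhibitor), compound 1 gives 32900 nM, the highest of the three numbers recorded so far. Compound 2 `O=C1C=CC2(C=C1)OC(=O)C(c1ccc([N+](=O)[O-])cc1)=C2c1ccccc1` gives 19000 nM in this assay, and compound 3 `O=C1C=CC2(C=C1)OC(=O)C(c1ccc(C(=O)O)cc1)=C2c1ccccc1` gives 15200 nM. The change a 1.7-fold lower number from compound 1 to compound 2 (0.24 log units; within the scatter) stays within the scatter, whereas a 2.2-fold lower number from compound 1 to compound 3 (0.34 log units; beyond the scatter) is modest but beyond it; between the two phenyl-bearing compounds, a 1.3-fold lower number from compound 2 to compound 3 (0.10 log units; within the scatter) is within the scatter.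

Compound 4 `O=Cc1ccc(C2=C(c3ccccc3)C3(C=CC(=O)C=C3)OC2=O)s1` differs from compound 1 in one place: 5-formylthiophen-2-yl in place of 1-benzothiophen-2-yl on a double-bonded ring carbon. Among the compounds with values here, the only steps that bear on this are the two in which the 1-benzothiophen-2-yl group of compound 1 gave way to a substituted phenyl, namely a 1.7-fold lower number from compound 1 to compound 2 (0.24 log units; within the scatter) and a 2.2-fold lower number from compound 1 to compound 3 (0.34 log units; beyond the scatter). Both point the same way, one within the scatter and one just beyond it. No thiophene bearing a formyl group has been measured, so the expectation rests on those two steps alone. A step of similar size, a 1.6-fold lower number from compound 1 to compound 4 (0.22 log units; within the scatter), is expected for the move to compound 4. On that basis compound 4 is estimated at 20000 nM in this assay, with a range from 8000 nM to 50000 nM.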

Compound 4, half-maximal inhibitory concentration: 19800 nM
The estimate for compound 4 lay 1.0-fold (0.00 log units) above the measured number; low and high end bracket the measured number.
By their numbers in this assay, from the lowest: compounds 3, 2, 4 and 1 (each within the scatter of the next, the first and the last beyond it).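

With a 1.7-fold lower number from compound 1 to compound 4 (0.22 log units; within the scatter) in this assay, the loss of the six-membered aromatic ring of the 1-benzothiophen-2-yl group, taken together with the gain of a formyl group on the remaining five-membered ring, does not move the number beyond the scatter. Within the data shown here, the 5-formylthiophen-2-yl group also cannot be told apart from either substituted phenyl, with a 1.3-fold higher number from compound 3 to compound 4 (0.11 log units; within the scatter) and a 1.0-fold higher number from compound 2 to compound 4 (0.02 log units; within the scatter) both within the scatter, so at this position a sulfur-containing five-membered ring serves as well as a substituted phenyl, and the pair of compound 1 and compound 3 remains the only one of the four compounds set apart beyond the scatter. No measurement at hand accounts for how closely these different groups agree.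

The step to compound 4 changes the ring and adds the formyl group at once. An unsubstituted thiophen-2-yl group would be needed to separate the two changes. Going by these compounds, it also remains open whether a group of another kind on this carbon, such as an amine or a short alkyl chain, would take the number outside the narrow range seen so far.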